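The compounds below may be only part of what the source reports. "The series", "measured", "known", "first", "only" and "open" are said of these compounds alone.

Of the compounds shown here, three of one shared core have been tested in a functional assay on HCT-116 cells (Homo sapiens) for cytotoxicity, read by sulforhodamine B assay, with a stated time of 48 h; a higher number here means a weaker inhibitor, a lower number a stronger inhibitor. Compound 1 `COc1ccc(/C=C/C(=O)/C=C/c2ccc(OCc3cn(CCOc4cc(=O)oc5ccccc45)nn3)c(OC)c2)cc1OC` gives 4710 nM, compound 2 `COc1ccc(/C=C/C(=O)/C=C/c2ccc(OCc3cn(CCOc4cc(=O)oc5ccccc45)nn3)c(OC)c2)cc1` gives 9290 nM, and compound 3 `COc1cc(/C=C/C(=O)/C=C/c2cccc3ccccc23)ccc1OCc1cn(CCOc2cc(=O)oc3ccccc23)nn1` gives 6540 nM. Compound 3 thus stands second highest of the three numbers, and its neighbours lie close on both sides: a 1.4-fold higher number from compound 1 to compound 3 (0.14 log units; within the scatter) and a 1.4-fold lower number from compound 2 to compound 3 (0.15 log units; within the scatter) both stay within the scatter, so the three compounds cannot be told apart on these data.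

Compound 4 `COc1cccc(/C=C/C(=O)/C=C/c2ccc(OCc3cn(CCOc4cc(=O)oc5ccccc45)nn3)c(OC)c2)c1` has not yet been measured. It differs from compound 3 in one place: 3-methoxyphenyl in place of naphthalen-1-yl on a double-bonded chain carbon bound to a double-bonded chain carbon.

Among the measured compounds shown here, two measured steps bear on this change, since both reach the same naphthalen-1-yl group of compound 3 from a phenyl ring carrying methoxy groups at that same chain position. Neither a 1.4-fold higher number from compound 1 to compound 3 (0.14 log units; within the scatter) nor a 1.4-fold lower number from compound 2 to compound 3 (0.15 log units; within the scatter) moved the number beyond the scatter. The change to compound 4 runs the other way, swapping the naphthalen-1-yl back for a phenyl ring bearing a single methoxy group, so no step beyond the scatter is expected in this assay, in either direction.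

Compound 4 is therefore estimated at 7000 nM, with a range from 3500 nM to 14000 nM, which means an expected step of a 1.1-fold higher number from compound 3 to compound 4 (0.03 log units; within the scatter).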

Compound 4, half-maximal inhibitory concentration: 9760 nM
Compound 4: middle estimate off by 1.4-fold (0.14 log units), on the low side; the range from low to high includes it.
By their numbers in this assay, from the lowest: compounds 1, 3, 2 and 4 (each within the scatter of the next, the first and the last beyond it).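

In this assay, among the compounds shown here, the change from 3,4-dimethoxyphenyl to 3-methoxyphenyl gives a 2.1-fold higher number from compound 1 to compound 4 (0.32 log units; beyond the scatter) and so becomes the first step at this chain position to pass beyond the scatter, though only modestly. The two rings with a single methoxy group cannot be told apart, since a 1.1-fold higher number from compound 2 to compound 4 (0.02 log units; within the scatter) stays within the scatter, and the exchange of naphthalen-1-yl for 3-methoxyphenyl, a 1.5-fold higher number from compound 3 to compound 4 (0.17 log units; within the scatter) as well, stays within it too. Compound 4 therefore adds one separated pair, with compound 1, but no firm ranking of the groups at this position, as every other pair here remains within the scatter.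

The compounds shown leave open how this position would respond to a plain phenyl ring, or to a phenyl ring carrying an amine or a carboxylic acid in place of methoxy. No measurement shown here accounts for the modest step between compound 1 and compound 4.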